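The source may hold more compounds than are shown below. What is called first, only, known or untested is meant among the compounds shown, and "the series" means these compounds.

Compound 1 `C=CC(=O)Nc1cccc(Oc2nc(Nc3ccn(C)n3)nc3c2CSCC3)c1`: > 50000 nM
Compound 2 `CC(C)=CC(=O)Nc1cccc(Oc2nc(Nc3ccn(C)n3)nc3c2CSCC3)c1`: > 50000 nM

In an ADME assay on L02 cells (Homo sapiens) for cytotoxicity, read by MTT assay, with a stated time of 72 h (a higher number here means a weaker inhibitor, a lower number a stronger inhibitor), compound 2 gives > 50000 nM as a limit of the assay and not a number. Compound 1 gives > 50000 nM as a limit too. The evidence so far is the limit of > 50000 nM in this assay, at which 2 of the 2 values shown sit, and nothing else. Compound 3 `C=C(F)C(=O)Nc1cccc(Oc2nc(Nc3ccn(C)n3)nc3c2CSCC3)c1` differs from compound 2 by 1-fluoroethenyl in place of 2-methylprop-1-en-1-yl on a carbonyl carbon with 1-fluoroethenyl in place of 2-methylprop-1-en-1-yl on a carbonyl carbon. Among the measured compounds shown here, the one measured step at this place is a step that the two limits leave unreadable from compound 1 to compound 2 and it has no readable size. In this assay no change beyond the scatter is therefore expected, and the estimated step is a number no higher from compound 2 to compound 3 (the limit leaves the size open) in no clear direction. Compound 3 is estimated at 50000 nM with an expected range of 20000 nM to 100000 nM and may again read as a limit.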

Compound 3, half-maximal inhibitory concentration: 47800 nM
For compound 3 the middle estimate is 1.0-fold (0.02 log units) above the measured one; low and high end bracket the measured number.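

In this assay, among the compounds shown here, compound 3 is the only one of the three compounds to give a number rather than a limit, so 1-fluoroethenyl on the carbonyl carbon gives a readable value. The data show an at least 1.0-fold lower number from compound 2 to compound 3 (0.01 log units; that floor lies within the scatter) and an at least 1.0-fold lower number from compound 1 to compound 3 (0.01 log units; that floor lies within the scatter), so neither step establishes a real change. The step from compound 1 to compound 2 cannot be read, and the picture still rests largely on a limit: the limit of > 50000 nM in this assay, at which 2 of the 3 values shown sit.

Going by these compounds, whether chloro in place of the fluoro, or a dimethylamino group on the end of the chain, would give a number in this assay stays open.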